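The source may report more compounds than this note shows. Statements on the series, on what has been measured and on what is new or still open speak of the compounds shown alone.

Measured in an assay on isolated protein for inhibition of thiosulfate sulfurtransferase (Homo sapiens), with a stated time of 60 min, in the absence of a further agent; a lower number here means a stronger inhibitor, a higher number a weaker inhibitor:
compound 1 `COc1c(Br)cc(Br)cc1C(=O)Nc1ccccc1` gives > 100000 nM, a limit rather than a number.
compound 2 `COc1ccc(Br)cc1C(=O)Nc1ccccc1` gives > 100000 nM, again a limit rather than a number.

Compound 2 thus stands only at the limit of this assay, without a number. The step that the two limits leave unreadable from compound 1 to compound 2 cannot be read because of the limit of > 100000 nM in this assay, at which 2 of the 2 values shown sit. Compound 3 `COc1ccccc1C(=O)Nc1ccccc1` differs from compound 2 by hydrogen in place of bromo on an aromatic carbon. For the measured compounds named here, the one measured step of this kind gives no readable size, so no shift beyond the scatter can be expected in this assay, and a further limit is the likely outcome. For compound 3 the expected value is 150000 nM, estimated range 40000 nM to 600000 nM. The step that the limit leaves unreadable from compound 2 to compound 3 is expected to stay within the scatter.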

Compound 3, half-maximal inhibitory concentration: > 100000 nM
Compound 3 gave a limit, no number; the forecaster's own chance of this, stated with the estimate: 85%; the middle value is on the limit's open side.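

The step from compound 2 to compound 3 cannot be read, because both stand at a limit rather than a number: the limit of > 100000 nM in this assay, at which 3 of the 3 values shown sit. The compounds shown leave open which change to the shared core, if any, would give a numerical value in this assay.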